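Working notes: from compound 2 toward compound 3

The source may hold more compounds than are shown below. What is called first, only, known or untested is meant among the compounds shown, and "the series" means these compounds.

Two compounds have numbers in an assay on membranes from HeLa cells for displacement of a labelled ligand from adenosine receptor A3 (Homo sapiens), read by scintillation counting, with a stated time of 180 min, tested at 1 uM; on this read-out lower numbers stand for less inhibition and higher numbers for more inhibition at the one concentration tested (going by the name of the read-out). Compound 1 `CCN(CC)C(=O)C1=C(C)NC(=O)NC1c1ccoc1` gives 37%. Compound 2 `CCN(CC)C(=O)C1=C(C)NC(=O)NC1c1ccsc1` gives 35%. Within the data shown here, the only measured step, a number 2 percentage points lower from compound 1 to compound 2 (within the scatter), lies within the scatter. Compound 2 thus stands lowest of the two numbers, but its nearest neighbour, compound 1, sits within the scatter of it, so no order between the two can be read.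

Compound 3 `CC1=C(C(=O)OCC2CC2)C(c2ccsc2)NC(=O)N1` is not yet measured. It differs from compound 2 in one place: cyclopropylmethoxy in place of diethylamino on a carbonyl carbon. Among the measured compounds shown here, no measured step touches this carbonyl carbon; the one step on record, a number 2 percentage points lower from compound 1 to compound 2 (within the scatter), concerns the saturated ring carbon and so does not bear on the change. With nothing to set a direction, the expectation for this assay rests on compound 2 alone, whose value is 35%. The step is therefore estimated as no change at the digits printed from compound 2 to compound 3 (within the scatter), carrying a wide spread. Compound 3 is expected to give 35%, with an estimated range from 10% to 60%.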

Compound 3, a percentage reported as inhibition, at one concentration (the size of the read-out at that concentration, not a potency): 3%
Estimate against measurement, compound 3: 32 percentage points above, outside the stated range (below it).
By their numbers in this assay, from the lowest: compound 3; then compounds 2 and 1 (each within the scatter of the next).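

In this assay, among these compounds, cyclopropylmethoxy in place of diethylamino on the carbonyl carbon gives a number 32 percentage points lower from compound 2 to compound 3 (beyond the scatter) and so is the first change to exceed the scatter; the one earlier step, at the saturated ring carbon, did not. The read-out therefore responds to what sits on this carbonyl carbon, even though the leaving and entering groups have the same heavy-atom count and differ instead in nitrogen against oxygen, the three-membered ring and the hydrogen-bond acceptor. Nothing at hand ties the drop to any one of these differences.

Going by these compounds, whether the drop goes with the loss of the nitrogen on the carbonyl carbon or with the arrival of the cyclopropyl ring stays open, and cyclopropylmethylamino or ethoxy on that carbon would separate the two. Also open, on these data alone, are whether the step holds with furan-3-yl in place of thiophen-3-yl on the saturated ring carbon, and how a carboxylic acid or a longer alkoxy chain on the carbonyl carbon would read.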